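The compounds below may be only part of what the source reports. "The series", "measured", "known", "first", "only" and "open" are said of these compounds alone.

Three compounds share one core and differ in a few outer groups. Compound 1 `O=C(Nc1cccc(-n2cc(-c3ccncc3)c(-c3cc(O)cc(Cl)c3)n2)c1)Nc1ccc(Cl)c(C(F)(F)F)c1` carries a chloro and a trifluoromethyl, and in a functional assay on OVCAR-4 cells (Homo sapiens) for inhibition, read by sulforhodamine B assay, with a stated time of 48 h, tested at 10 uM (a lower number here means a stronger effect, a higher number a weaker effect of the compound at the concentration tested), compound 1 gives 31.6%. Compound 2 `O=C(Nc1cccc(-n2cc(-c3ccncc3)c(-c3cc(O)cc(Cl)c3)n2)c1)Nc1ccc(Cl)c(Cl)c1` carries two chloro groups instead, and in this assay compound 2 gives 10.7%; that single swap was a number 20.9 percentage points lower from compound 1 to compound 2 (beyond the scatter), so the second chloro went with a stronger effect. Compound 3 `COc1cc(Cl)cc(-c2nn(-c3cccc(NC(=O)Nc4cc(C(F)(F)F)cc(C(F)(F)F)c4)c3)cc2-c2ccncc2)c1`, which bears two trifluoromethyl groups and a methoxy where the others carry a hydroxy, gives 11.9% in this assay. Among the three, compound 3 stands second highest; its number sits close to that of compound 2, a difference within the scatter, while compound 1 lies well above it, beyond the scatter.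

Compound 4 `COc1cc(Cl)cc(-c2nn(-c3cccc(NC(=O)Nc4cccc(C(F)(F)F)c4)c3)cc2-c2ccncc2)c1` differs from compound 3 in one place: hydrogen in place of trifluoromethyl on an aromatic carbon. Among the compounds with values here, no measured pair makes exactly this change. The nearest is the step from compound 1 to compound 2, where a trifluoromethyl gave way to chloro and the number fell. Removing a trifluoromethyl altogether, with only hydrogen entering, is a different matter, and its direction cannot be read from that step alone. The expectation is therefore for a modest rise, a step of a number 13.1 percentage points higher from compound 3 to compound 4 (beyond the scatter), with wide uncertainty. Compound 4 is estimated to give 25% in this assay, between 5% and 55%.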

Compound 4, a percentage reported as activity, at one concentration (the size of the read-out at that concentration, not a potency): 3.28%
Beside the measured number, compound 4's estimate is 21.7 percentage points above it; the measured number lies below the stated range.
By their numbers in this assay, from the lowest: compounds 4, 2 and 3 (each within the scatter of the next); then compound 1.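

In this assay, taking one trifluoromethyl off the outer ring of compound 3 and leaving only hydrogen there gives a number 8.6 percentage points lower from compound 3 to compound 4 (within the scatter). So at this place on a six-membered aromatic ring of carbon only, the trifluoromethyl group can be lost, four heavy atoms in all, without a change that stands out from the scatter, and the single remaining trifluoromethyl in compound 4 goes with a number as low as that of compound 3. Within the data shown here, this differs from the only earlier single change, a number 20.9 percentage points lower from compound 1 to compound 2 (beyond the scatter), where a swap on the outer ring of compounds carrying a hydroxy did move the number beyond the scatter, so a change to a trifluoromethyl group on this ring does not always shift the result in the same way.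

Nothing measured here explains why this group can go with so little effect on the number.

On these data alone, whether a methyl, a methoxy, an amine or a carboxylic acid at this place would keep the number as low remains open. Also open, as far as these compounds go, is whether the same removal would behave alike in compounds carrying a hydroxy rather than a methoxy.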